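Replacing the Ester Side Chain with Cyclohexylmethyl

The compounds below may be only part of what the source reports. "The series", "measured", "known", "first", "only" and "open" are said of these compounds alone.

Compound 1 `COC(=O)[C@H](CCSC)NC(=O)c1ccc(NCc2cncn2Cc2ccc(C#N)cc2)cc1-c1ccccc1` gives > 10 uM in a functional assay on NIH3T3 cells (Mus musculus) (a lower number here means that less compound is needed, a higher number that more compound is needed for the effect), a limit of the assay rather than a number.
Compound 2 `CSCC[C@H](NC(=O)c1ccc(NCc2cncn2Cc2cccc(C#N)c2)cc1-c1ccccc1)C(=O)O` gives > 10 uM in this assay, again a limit.
Compound 3 `COC(=O)[C@H](CCSC)NC(=O)c1ccc(NCc2cncn2Cc2ccc(Cl)cc2)cc1-c1ccccc1` gives > 10 uM in this assay, also a limit.

Compound 1 therefore stands at the limit of the measurement, and the same holds for the two other values shown: the limit of > 10 uM in this assay, at which 3 of the 3 values shown sit. Going by the values given here, the only single-point step among the measured compounds, a step that the two limits leave unreadable from compound 1 to compound 3, cannot be read, since both ends are limits. Compound 2 shares no listed step with compound 1 and contributes only its own limit.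

Compound 4 `N#Cc1ccc(Cn2cncc2CNc2ccc(C(=O)NCC3CCCCC3)c(-c3ccccc3)c2)cc1` differs from compound 1 in one place: cyclohexylmethyl in place of 1-(methoxycarbonyl)-3-(methylsulfanyl)propyl on an amide-type nitrogen. Among the compounds with values here, none of the measured steps touches this position; all three measured compounds carry the same group on the amide-type nitrogen. From the measured compounds no direction or size can be derived for this change. The step that the limit leaves unreadable from compound 1 to compound 4 is therefore only an expected one, resting on the shared limit of the three measured compounds. Compound 4 is estimated at 15 uM, within a range of 2 uM to 100 uM, with a substantial chance that only a limit is again reported.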

Compound 4, concentration for half-maximal effect: > 10 uM
Compound 4: no number, only a limit; the forecaster's own chance of this, stated with the estimate: 65%; the middle value is on the limit's open side.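

Compound 4 gives only a limit in this assay, and so does compound 1, so the swap to cyclohexylmethyl cannot be read as a step. Left open are the actual concentrations these compounds need and whether this side chain matters at all: the limit of > 10 uM in this assay, at which 4 of the 4 values shown sit.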